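Chloro on the N-phenyl ring of compound 2

The compounds below may be only part of what the source reports. "The series", "measured", "known", "first", "only" and "open" are said of these compounds alone.

Measured in an ADME assay on HaCaT cells (Homo sapiens) for inhibition, read by sulforhodamine B assay, with a stated time of 48 h; on this read-out higher numbers stand for weaker inhibition of growth and lower numbers for stronger inhibition of growth:
- Compound 1 `CCOC(=O)c1nn(-c2ccccc2)c(-c2ccc(OC)cc2)c1CNC(C)(C)C`: 68300 nM; 19200 nM (2 entries)
- Compound 2 `COc1ccc(-c2c(CNC(C)(C)C)c(C(=O)O)nn2-c2ccccc2)cc1`: > 659000 nM, a limit
- Compound 3 `CC(C)(C)NCc1c(C(=O)O)nn(-c2ccccc2)c1-c1ccc([N+](=O)[O-])cc1`: > 634000 nM, a limit

Compound 2 has no number in this assay. Its entry of > 659000 nM is a limit of the assay. Compound 3 is likewise reported only as a limit, > 634000 nM. Compound 1 alone gives numbers, (the several entries of compound 1 in this assay, 68300 nM; 19200 nM (2 entries)).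

Compound 4 `COc1ccc(-c2c(CNC(C)(C)C)c(C(=O)O)nn2-c2ccc(Cl)cc2)cc1` departs from compound 2 by chloro in place of hydrogen on an aromatic carbon, so that phenyl becomes 4-chlorophenyl. Going by the values given here, the only measured step that bears on this is a step that the two limits leave unreadable from compound 2 to compound 3, and it is a different change, nitro in place of methoxy on an aromatic carbon. It gives no size to carry over, but it does show that this change left the reading at a limit. No step beyond the scatter is therefore expected in this assay, and a further limit is the likely report.

The expected result is an at least 1.0-fold lower number from compound 2 to compound 4 (0.04 log units; that floor lies within the scatter). For compound 4 the estimate is 600000 nM, with an expected range of 250000 nM to 1000000 nM.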

Compound 4, concentration for 50% growth inhibition: 121000 nM
The estimate for compound 4 lay 5.0-fold (0.70 log units) above the measured number, outside the stated range (below it).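

In this assay, the change from phenyl to 4-chlorophenyl gives an at least 5.4-fold lower number from compound 2 to compound 4 (0.73 log units; beyond the scatter), so a single chloro on this aromatic carbon, para to a large group, moves the reading beyond the scatter. Among the carboxylic acids shown, compound 4 alone gives a number, 121000 nM. Compound 2 and compound 3 stand only as limits of the assay. The size of the step is only a floor, with a limit of the assay at its one end: the limit of > 659000 nM in this assay, at which 1 of the 4 values shown sits.

The compounds shown leave open whether fluoro, bromo or methyl at this place would lower the number as chloro does. They also leave open whether chloro would lower it on the ethyl ester of compound 1, which already gives 68300 nM; 19200 nM (2 entries).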